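Moving the methoxy group on the pendant phenyl ring

The compounds below may be only part of what the source reports. "The series", "measured", "known", "first", "only" and "open" are said of these compounds alone.

Compound 2 `CCc1ccc2[nH]c(-c3ccc(OC)cc3)c(C3=C(Br)C(=O)NC3=O)c2c1` stands lowest of the three compounds measured in a physicochemical assay for lipophilicity (on this read-out higher numbers stand for higher lipophilicity and lower numbers for lower lipophilicity), where compound 2 gives 3.23. Its nearest neighbour is compound 1 `CCCCCOc1ccc2[nH]c(-c3ccc(OC)cc3)c(C3=C(Br)C(=O)NC3=O)c2c1`, which gives 3.77, and the furthest is compound 3 `CCCCCc1ccc2[nH]c(-c3ccc(OC)cc3)c(C3=C(Br)C(=O)NC3=O)c2c1`, which gives 4.1. The three measured steps all concern the chain on the shared core: a number 0.54 log units lower from compound 1 to compound 2 (beyond the scatter), a number 0.33 log units higher from compound 1 to compound 3 (beyond the scatter) and a number 0.87 log units higher from compound 2 to compound 3 (beyond the scatter).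

Compound 4 `CCc1ccc2[nH]c(-c3cccc(OC)c3)c(C3=C(Br)C(=O)NC3=O)c2c1` differs from compound 2 in another place altogether: 3-methoxyphenyl in place of 4-methoxyphenyl on an aromatic carbon. Among the measured compounds shown here, none of the measured steps bears on this change. Each of them replaces or lengthens a chain, with a change in the number of atoms, whereas the step from compound 2 to compound 4 keeps the same atoms and only rearranges them within the methoxyphenyl group. The expectation for compound 4 therefore rests directly on the value compound 2 shows in this assay, 3.23, with no evidence from the other compounds to push it either way. The step from compound 2 to compound 4 is expected to be a number 0.02 log units higher from compound 2 to compound 4 (within the scatter), that is, nothing beyond the scatter. Compound 4 is expected to give about 3.25 in this assay, within a range from 2.95 to 3.55.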

Compound 4, partition coefficient: 3.35
The estimate for compound 4 lay 0.10 log units below the measured number; the range from low to high includes it.
By their numbers in this assay, from the lowest: compounds 2 and 4 (each within the scatter of the next); then compound 1; then compound 3.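

With the ethyl chain held fixed, 3-methoxyphenyl in place of 4-methoxyphenyl gives a number 0.12 log units higher from compound 2 to compound 4 (within the scatter) in this assay, so on this read-out the two methoxyphenyl groups cannot be told apart. Among the compounds shown here, the earlier steps all concerned the chain on the shared core and all lay beyond the scatter, whereas this is the first reading at the position on an aromatic carbon of the five-membered ring, next to the ring nitrogen, and the first change that keeps the same atoms and only joins them differently. Nothing available explains why the step stays within the scatter.

From the compounds shown here alone, the step rests on a single pair carrying the ethyl chain, so it remains open whether moving the methoxy group would again stay within the scatter with the pentyl chain of compound 3 or the pentyloxy chain of compound 1. Going by these compounds, it also remains open how this assay would respond if a carboxylic acid, an amine or a longer alkoxy chain stood on the pendant phenyl ring in place of the methoxy group.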